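Replacing 2-nitrophenyl with 3-chlorophenyl in a growth-inhibition series

The compounds below may be only part of what the source reports. "The series", "measured", "known", "first", "only" and "open" are said of these compounds alone.

In a functional assay on UACC-62 cells (Homo sapiens) for cytotoxicity, read by sulforhodamine B assay (a lower number here means a stronger inhibitor of growth, a higher number a weaker inhibitor of growth), compound 3 (`CC1=CC[C@@H]([C@@](C)(O)CCCC(C)(C)NC(=S)N/N=C\c2ccccc2[N+](=O)[O-])CC1`) gives 16600 nM as the lowest of three numbers. In this assay compound 2 (`CC1=CC[C@@H]([C@@](C)(O)CCCC(C)(C)NC(=S)N/N=C\c2ccc(C)cc2)CC1`) gives 39000 nM and compound 1 (`CC1=CC[C@@H]([C@@](C)(O)CCCC(C)(C)NC=S)CC1`) gives 42500 nM as well. Compound 4 (`CC1=CC[C@@H]([C@@](C)(O)CCCC(C)(C)NC(=S)N/N=C\c2cccc(Cl)c2)CC1`) has not yet been measured. It carries 3-chlorophenyl in place of 2-nitrophenyl on a carbon with a double bond to nitrogen. For the measured compounds named here, one measured step bears on this change: the replacement of 4-methylphenyl by 2-nitrophenyl at that carbon (a 2.3-fold lower number from compound 2 to compound 3 (0.37 log units; beyond the scatter)) is modest but beyond the scatter. Going by the values given here, no measured compound carries 3-chlorophenyl, so the size of its effect remains open. Among the compounds with values here, with compound 2 at 39000 nM and compound 3 at 16600 nM as the only guides, compound 4 is expected to fall within the span of those two values. The expected step (a 1.5-fold higher number from compound 3 to compound 4 (0.18 log units; within the scatter)) is none beyond the scatter. For compound 4 the estimated value is 25000 nM with an expected range of 13000 nM to 45000 nM in this assay.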

Compound 4, concentration for total growth inhibition: 18100 nM
Beside the measured number, compound 4's estimate is 1.4-fold (0.14 log units) above it; the measured number falls inside the stated range.
By their numbers in this assay, from the lowest: compounds 3 and 4 (each within the scatter of the next); then compounds 2 and 1 (each within the scatter of the next).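

In this assay, the place on a carbon with a double bond to nitrogen takes 3-chlorophenyl as readily as 2-nitrophenyl: a 1.1-fold higher number from compound 3 to compound 4 (0.04 log units; within the scatter) shows no separable change, although 2-nitrophenyl counts hydrogen-bond acceptors and 3-chlorophenyl counts none. Measured against 4-methylphenyl, 3-chlorophenyl gives a 2.2-fold lower number from compound 2 to compound 4 (0.33 log units; beyond the scatter) so two different groups now stand on the same side of compound 2, and a nitro group is not needed for the lower number. Nothing measured here explains why 2-nitrophenyl and 3-chlorophenyl read alike.

From the compounds shown here alone, whether an unsubstituted phenyl would read with these two groups or with 4-methylphenyl stays open. So does the outcome for 4-chlorophenyl, or for a phenyl bearing an amine or a carboxylic acid, at this same place.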